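This account rests on a few compounds, and the source may have more. Where it says the series, first, only, none or still open, it means among the compounds named here.

The account begins with compound 1, whose structure is `C[C@H]1[C@H](NCc2cncs2)C[C@H]2C[C@@H]1C2(C)C`. In an ADME assay on MDCK cells (Canis lupus familiaris) for cytotoxicity, read by microscopy, with a stated time of 48 h (a higher number here means that more compound is tolerated, a lower number that less compound is tolerated), compound 1 gives > 100000 nM, a value that is a limit of the assay rather than a number. Compound 2, with structure `C[C@H]1[C@H](NCc2sccc2-c2ccccc2)C[C@H]2C[C@@H]1C2(C)C`, belongs to the same series; in this assay compound 2 gives 12500 nM. Going by the values given here, the two readings differ in kind, and no step between them is set out here, so only the two values themselves are known.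

Compound 3, whose structure is `Cc1csc(CN[C@@H]2C[C@H]3C[C@@H]([C@H]2C)C3(C)C)n1`, has not yet been measured. It differs from compound 1 in one place: 4-methyl-1,3-thiazol-2-yl in place of 1,3-thiazol-5-yl on a saturated chain carbon bound to an amine nitrogen. Among the compounds with values here, no measured pair shows what this kind of change does in this assay, so the step has to be judged from compound 1 alone, which stands at the limit of > 100000 nM in this assay, at which 1 of the 2 values shown sits.

The expectation for compound 3 is a step of a number no higher from compound 1 to compound 3 (the limit leaves the size open), which is to say none beyond the scatter. Compound 3 is therefore estimated at 100000 nM, with a range from 40000 nM to 200000 nM, and a fair chance that only a limit is reported again.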

Compound 3, minimum cytotoxic concentration: > 100000 nM
Compound 3 ended at the assay's limit; the forecaster's own chance of this, stated with the estimate: 60%; the middle value lies on the limit itself.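

In this assay compound 3 gives > 100000 nM, a limit of the assay and not a number. Going by these compounds alone, compound 1 also stands at a limit, so no step from compound 1 to compound 3 can be read. The compounds shown leave open whether 4-methyl-1,3-thiazol-2-yl in place of 1,3-thiazol-5-yl changes the reading in this assay at all.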